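A 2-nitrophenyl swap on the ring nitrogen

The source may report more compounds than this note shows. Statements on the series, on what has been measured and on what is new or still open speak of the compounds shown alone.

In a functional assay on MCF7 cells (Homo sapiens) for antiproliferative activity, read by MTT assay, with a stated time of 72 h (a lower number here means a stronger inhibitor, a higher number a weaker inhibitor), compound 1 `Nc1nc(N)c2cc(CSC(=S)N3CCN(C4CCCCC4)CC3)ccc2n1` reads 6800 nM and compound 2 `Nc1nc(N)c2cc(CSC(=S)N3CCN(c4ccc(F)cc4F)CC3)ccc2n1` reads 3670 nM in the same test, so the two stand level. Among the compounds with values here, the only measured step, a 1.9-fold lower number from compound 1 to compound 2 (0.27 log units; within the scatter) for a swap at the same place, lies within the scatter. Compound 3 `Nc1nc(N)c2cc(CSC(=S)N3CCN(c4ccccc4[N+](=O)[O-])CC3)ccc2n1` carries 2-nitrophenyl in place of 2,4-difluorophenyl on an amine nitrogen in a ring and has not been measured. Within the data shown here, with only that one step as a guide, no change beyond the scatter is expected in this assay here. Compound 3 is estimated at 4000 nM with an expected range of 1600 nM to 10000 nM for repeat measurements. The expected change is a 1.1-fold higher number from compound 2 to compound 3 (0.04 log units; within the scatter) and no more.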

Compound 3, half-maximal inhibitory concentration: 4350 nM
The estimate for compound 3 lay 1.1-fold (0.04 log units) below the measured number, and the stated range covers the measured number.
By their numbers in this assay, from the lowest: compounds 2, 3 and 1 (each within the scatter of the next).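

Replacing the two fluorines with a nitro group changes the substituent on the phenyl ring, and the reading stays within the scatter (a 1.2-fold higher number from compound 2 to compound 3 (0.07 log units; within the scatter)). The 2-nitrophenyl group, which brings the two hydrogen-bond acceptors counted for it, also stays within the scatter of the cyclohexyl group (a 1.6-fold lower number from compound 1 to compound 3 (0.19 log units; within the scatter)), so all three groups on this ring nitrogen read alike in this assay. Nothing here explains why these groups read alike. Going by these compounds, it remains open whether any group on this nitrogen can move the number beyond the scatter. A phenyl ring carrying an amine or a carboxylic acid, or a longer chain in this place, would test that.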